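This account rests on a few compounds, and the source may have more. Where it says the series, first, only, none or still open, it means among the compounds named here.

Of the compounds shown here, three have been tested in a functional assay on MCF7 cells (Homo sapiens) for antiproliferative activity, read by MTT assay, with a stated time of 72 h; on this read-out lower numbers stand for stronger inhibition and higher numbers for weaker inhibition. Compound 1 `O=c1cc(CSC(=S)N2CCCCC2)oc2cc(Cl)ccc12` carries piperidin-1-yl on the thiocarbonyl carbon and chloro on an aromatic carbon. In this assay compound 1 gives only a limit, > 25000 nM. Compound 2 `O=c1cc(CSC(=S)N2CCCC2)oc2ccccc12` carries pyrrolidin-1-yl on the thiocarbonyl carbon and hydrogen on the aromatic carbon; in this assay compound 2 gives 35800 nM. Compound 3 `O=c1cc(CSC(=S)N2CCCC2)oc2cc(Cl)ccc12` joins pyrrolidin-1-yl to the core of compound 1. In this assay compound 3 gives only a limit, > 25000 nM. The step that the two limits leave unreadable from compound 1 to compound 3 is therefore unreadable, and so is the step that the limit leaves unreadable from compound 2 to compound 3; both rest on (the limit of > 25000 nM in this assay, at which 2 of the 3 values shown sit). Compound 3 thus stands at the limit, with no number of its own.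

Compound 4 `CCN(CC)C(=S)SCc1cc(=O)c2ccc(Cl)cc2o1` differs from compound 3 in one place: diethylamino in place of pyrrolidin-1-yl on a thiocarbonyl carbon. Neither measured step bears directly on this exchange, since each changes a different group and neither has a readable size. Among the measured compounds shown here, the only guide is that compound 2, the one numbered value, lies weak, and the exchange of amines on the thiocarbonyl carbon so far has not brought anything into readable range. The step that the limit leaves unreadable from compound 3 to compound 4 is therefore expected to stay small. Compound 4 is estimated at 35000 nM, within 15000 nM to 90000 nM, and is expected most likely to be reported again as a limit.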

Compound 4, half-maximal inhibitory concentration: > 25000 nM
Compound 4: only a limit was reported; the forecaster's own chance of this, stated with the estimate: 70%; the middle value lies beyond the limit too.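

In this assay compound 4 gives only a limit, > 25000 nM, so its steps from compound 3 and compound 1 cannot be read: the limit of > 25000 nM in this assay, at which 3 of the 4 values shown sit. The compounds shown leave open how diethylamino, pyrrolidin-1-yl and piperidin-1-yl on the thiocarbonyl carbon rank against one another on the core of compound 1.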